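The source may hold more compounds than are shown below. What is called first, only, known or untested is meant among the compounds shown, and "the series" means these compounds.

Compound 1, `COc1ccc(-n2nc(C(=O)Nc3ccccc3C)nc2-c2cc(OC)c(OC)c(OC)c2)cc1`, gives 64% in a functional assay on the whole organism for inhibition, with Rattus norvegicus as the target, read by paw edema, with stated times of 30 min and 3 h, at a dose of 0.28 mmol/kg by the oral route; a higher number here means more inhibition at the dose given (going by the name of the read-out), a lower number less inhibition.
Compound 2, `COc1ccc(-n2nc(C(=O)Nc3cccc(F)c3)nc2-c2cc(OC)c(OC)c(OC)c2)cc1`, gives 92% in this assay.

Among the measured compounds shown here, of the two measured compounds, compound 2 stands highest: the single step, a number 28 percentage points higher from compound 1 to compound 2 (beyond the scatter), lies beyond the scatter and shows that exchanging the group on the amide-type nitrogen can move the read-out by a modest margin. Compound 3, `COc1ccc(-n2nc(C(=O)Nc3ccc(C(F)(F)F)cc3)nc2-c2cc(OC)c(OC)c(OC)c2)cc1`, carries a further exchange at that same position: 4-(trifluoromethyl)phenyl in place of 3-fluorophenyl on an amide-type nitrogen. For the measured compounds named here, no measured step covers this particular exchange, so the only guidance is that the step from compound 1 to compound 2 was modest and that the amide-type aryl group is not inert here. With compound 2 already near the top of the scale, the expected direction for compound 3 is a mild fall, estimated as a number 14 percentage points lower from compound 2 to compound 3 (beyond the scatter). Compound 3 is therefore expected to give 78% in this assay, with a range from 55% to 95%.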

Compound 3, a percentage reported as inhibition, in the whole organism at one dose (the size of the read-out at that dose, not a potency): 83%
The estimate for compound 3 lay 5 percentage points below the measured number; the measured number falls inside the stated range.
By their numbers in this assay, from the lowest: compound 1; then compounds 3 and 2 (each within the scatter of the next).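

In this assay, exchanging 3-fluorophenyl for 4-(trifluoromethyl)phenyl on the amide-type nitrogen amounts to a number 9 percentage points lower from compound 2 to compound 3 (within the scatter), so this position accepts either group, although the entering one carries more heavy atoms and its fluorine sits differently named on the ring. The step of a number 19 percentage points higher from compound 1 to compound 3 (beyond the scatter) adds a second case beside compound 2: among the three compounds, both fluorine-bearing aryl groups give higher numbers than 2-methylphenyl, and none goes against this. Nothing at hand says why the read-out answers to this position as it does.

Still open, on these data alone, is whether an aryl group is needed here at all, which a cyclohexyl group or a short alkyl chain would test. Also open, as far as these compounds go, is whether plain phenyl, or a phenyl bearing an amine or a carboxylic acid, would hold the read-out at this level.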